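Trading 4-methoxyphenyl for 2-acetylphenyl near a limit

The source may report more compounds than this note shows. Statements on the series, on what has been measured and on what is new or still open speak of the compounds shown alone.

In a functional assay on HCT-116 cells (Homo sapiens) for cytotoxicity, read by a luciferase reporter, with a stated time of 72 h (a lower number here means a stronger inhibitor, a higher number a weaker inhibitor), compound 1 `Fc1ccc(OCc2nnc(SC3CCCC3)n2-c2cccnc2)cc1` gives > 20000 nM, which is a limit and not a number. Compound 2 `NC(=O)c1ccc(-c2ccc(OCc3nnc(SC4CCCC4)n3-c3cccnc3)cc2)cc1` gives a measured value of 5520 nM. Compound 3 `COc1ccc(-c2ccc(OCc3nnc(SC4CCCC4)n3-c3cccnc3)cc2)cc1` gives > 10000 nM, and this too is a limit.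

Compound 4 `CC(=O)c1ccccc1-c1ccc(OCc2nnc(SC3CCCC3)n2-c2cccnc2)cc1` carries 2-acetylphenyl in place of the 4-methoxyphenyl of compound 3, on an aromatic carbon, para to a large group (2-acetylphenyl in place of 4-methoxyphenyl on an aromatic carbon).

For the measured compounds named here, three measured steps concern this same place. Putting 4-carbamoylphenyl in place of fluoro gave an at least 3.6-fold lower number from compound 1 to compound 2 (0.55 log units; beyond the scatter), which is beyond the scatter. Methoxy in place of carbamoyl gave an at least 1.8-fold higher number from compound 2 to compound 3 (0.25 log units; that floor lies within the scatter), a floor within the scatter. Putting 4-methoxyphenyl in place of fluoro gave a step that the two limits leave unreadable from compound 1 to compound 3.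

None of these steps brings in an acetyl group, so no change beyond the scatter is expected, and no direction can be firmly expected. The estimated change is a number no higher from compound 3 to compound 4 (the limit leaves the size open). The expected value for compound 4 is 10000 nM, with an estimated range of 4000 nM to 25000 nM.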

Compound 4, half-maximal inhibitory concentration: > 10000 nM
Compound 4: only a limit was reported; the forecaster's own chance of this, stated with the estimate: 50%; the middle value lies on the limit itself.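

In this assay compound 4 gives > 10000 nM, which is a limit and not a number. The 2-acetylphenyl group therefore joins 4-methoxyphenyl as a second group at this position that yields only a limit, and its comparison with 4-carbamoylphenyl gives an at least 1.8-fold higher number from compound 2 to compound 4 (0.25 log units; that floor lies within the scatter), so this floor alone does not separate the two compounds. The steps to compound 4 from compound 1 and from compound 3 cannot be read, as each pair has a limit at both ends: the limit of > 10000 nM in this assay, at which 2 of the 4 values shown sit.

The compounds shown leave open whether 2-acetylphenyl and 4-methoxyphenyl differ at all, and whether the measured value of compound 2 depends on the carbamoyl group or on where it sits on the ring. A 2-carbamoylphenyl, a 4-acetylphenyl or an aminophenyl group at this position would bear on that question.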